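A few compounds are considered here, and "the series" means these few. Any claim that something is new, unique, unknown or untested is made for them only; others in the source may bear on it.

Compound 1, `C=CCc1cc(O)c(O)c(CN2CCC(CO)CC2)c1`, gives 37.7% in a functional assay on HL-60 cells (Homo sapiens) for inhibition, read by MTT assay, with a stated time of 72 h, tested at 30 uM; a lower number here means less inhibition of growth, a higher number more inhibition of growth at the concentration tested.
Compound 2, `C#CCOc1ccc(CC=C)cc1O`, gives 30.7% in this assay.
Compound 3, `C=CCc1ccc(OCc2cn(-c3ccc(C(=O)c4ccccc4)cc3)nn2)c(O)c1`, gives 38.3% in this assay.

All three compounds share an allyl-bearing phenol core and were tested at a single concentration, so each number says how much cell growth was held back at that dose. The three numbers sit close together: compound 3 nominally stands at the top, but its gap to compound 1 and its gap to compound 2 are both within the usual scatter of repeated measurements, so none of the three can be called more or less active than another.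

Compound 4, `C=CCc1ccc(OCc2cn(-c3ccc(C#N)cc3)nn2)c(O)c1`, has not yet been measured. It differs from compound 3 in one place: cyano in place of benzoyl on an aromatic carbon. Everything else, including the triazole linker and the phenol core, is kept.

Within the data shown here, no measured pair with a change of this kind is available, so there is nothing to say how large a step it brings. Among the measured compounds shown here, with the three known numbers all within the scatter of one another, the expectation is a step from compound 3 to compound 4 that stays within the scatter, with no clear direction, that is a number 3.3 percentage points lower from compound 3 to compound 4 (within the scatter). Compound 4 is therefore estimated to give about 35% in this assay, with a range from 22% to 48%.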

Compound 4, percent growth inhibition at one concentration: 20.8%
The estimate for compound 4 lay 14.2 percentage points above the measured number, outside the stated range (below it).
By their numbers in this assay, from the lowest: compounds 4, 2, 1 and 3 (each within the scatter of the next, the first and the last beyond it).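

Among these compounds, the change of benzoyl to cyano on this aromatic carbon, para to a large group, is the first one here that moves the number by more than the scatter in this assay: a number 17.5 percentage points lower from compound 3 to compound 4 (beyond the scatter). This position is therefore not indifferent to what sits on it, even though the three earlier compounds, with their quite different attachments to the shared core, could not show that. Benzoyl and cyano both count one hydrogen-bond acceptor and no donors, so that count does not separate them, while the heavy atoms drop from eight to two and a six-membered aromatic ring leaves; nothing available shows why the number goes down.

One pair cannot separate the loss of the ring from the loss of the carbonyl or from the smaller size of the group, and a plain phenyl, a methyl or a carboxylic acid on this carbon would be needed to tell these apart. From the compounds shown here alone, it also remains open whether the same swap would bring a similar step on a different core or at other concentrations.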